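Dibutylamino replaces (1-methylbutyl)amino on the carbonyl carbon

The source may report more compounds than this note shows. Statements on the series, on what has been measured and on what is new or still open speak of the compounds shown alone.

Compound 1 `COc1cc(C(=O)N2CCN(C(=O)c3cc(OC)c(OC)c(OC)c3)C(COC(=O)C(C)(C)C)C2)cc(OC)c1OC` serves as a reference point; in a functional assay (Oryctolagus cuniculus) for inhibition of platelet-activating factor receptor (Cavia porcellus) (a higher number here means a weaker inhibitor, a lower number a stronger inhibitor), compound 1 gives 100 nM; 100 nM; 120 nM (3 entries). Going by the values given here, compound 2 `CCCC(C)NC(=O)OCC1CN(C(=O)c2cc(OC)c(OC)c(OC)c2)CCN1C(=O)c1cc(OC)c(OC)c(OC)c1` is the starting point of the step followed here; in this assay compound 2 gives 100 nM, the only number it has, and that number sits within the scatter of the repeated readings of compound 1 (the several entries of compound 1 in this assay, 100 nM; 100 nM; 120 nM (3 entries)). Compound 3 `CCCCN(CCCC)C(=O)OCC1CN(C(=O)c2cc(OC)c(OC)c(OC)c2)CCN1C(=O)c1cc(OC)c(OC)c(OC)c1` differs from compound 2 in one place (dibutylamino in place of (1-methylbutyl)amino on a carbonyl carbon). Among the compounds with values here, no measured step of this kind is at hand. The step of a 1.5-fold higher number from compound 2 to compound 3 (0.18 log units; within the scatter) is expected to be small, toward weaker inhibition if anything. Compound 3 is estimated at 150 nM, within 60 nM to 400 nM.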

Compound 3, half-maximal inhibitory concentration: 1250 nM
Compound 3: middle estimate off by 8.3-fold (0.92 log units), on the low side; measured number above the stated range.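

In this assay, the group on this carbonyl carbon turns out not to be freely interchangeable: dibutylamino in place of (1-methylbutyl)amino gives a 13-fold higher number from compound 2 to compound 3 (1.10 log units; beyond the scatter). The change removes the hydrogen-bond donor and enlarges the group at once, so this single step cannot show which of the two matters. The step clearly exceeds the spread of the repeated readings of the reference compound: the several entries of compound 1 in this assay, 100 nM; 100 nM; 120 nM (3 entries).

On these data alone, it remains open how butylamino, which keeps the donor, or dimethylamino, which lacks it, would read at this place.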